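Chain Growth at Two Places in a Shared Core

The source may hold more compounds than are shown below. What is called first, only, known or untested is meant among the compounds shown, and "the series" means these compounds.

Measured so far:
Compound 1, `CCc1nn(C)c2c1C(c1ccccc1Cl)=NCC(=O)N2` — 2.5 mg/kg in a functional assay on the whole organism (strain Holtzman) with Rattus norvegicus as the target; a lower number here means that less compound is needed, a higher number that more compound is needed for the effect
Compound 2, `CC(C)c1nn(C)c2c1C(c1ccccc1Cl)=NCC(=O)N2` — > 40 mg/kg
Compound 3, `CCn1nc(C)c2c1NC(=O)CN=C2c1ccccc1Cl` — 5 mg/kg

The value of compound 2 is a limit of this assay, not a number. Compound 1 and compound 2 differ by methyl in place of hydrogen on a saturated chain carbon bound to an aromatic carbon and a saturated chain carbon; that change gave an at least 16-fold higher number from compound 1 to compound 2 (1.20 log units; beyond the scatter). Compound 3 and compound 4, `CCCn1nc(C)c2c1NC(=O)CN=C2c1ccccc1Cl`, differ by methyl in place of hydrogen on a saturated chain carbon, two bonds along the chain from an aromatic nitrogen. This is the same kind of change, but the place is not the same: in one the carbon is bound to an aromatic carbon and a saturated chain carbon, in the other it lies two bonds along the chain from an aromatic nitrogen. Compound 1 and compound 3 share their atoms joined differently; the difference between the two cores is not broken down here. For compound 4 a smaller step than the earlier one is expected, a 2.0-fold higher number from compound 3 to compound 4 (0.30 log units; within the scatter), since the place differs. Compound 4 is estimated at 10 mg/kg.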

Compound 4, minimum effective dose: 40 mg/kg
For compound 4 the middle estimate is 4.0-fold (0.60 log units) below the measured one, within the range that was stated.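

In this assay the step from ethyl to propyl gave an 8.0-fold higher number from compound 3 to compound 4 (0.90 log units; beyond the scatter) and so moved the number the same way as the earlier change from ethyl to the branched chain. Compound 2 gives > 40 mg/kg in this assay and that value is a limit of the assay, not a number. The direction of the change therefore carried over between these two cores, at two different places, but whether its size carried over is not shown: the same change on two cores in this assay, an at least 16-fold higher number (1.20 log units; beyond the scatter) from compound 1 to compound 2 and an 8.0-fold higher number (0.90 log units; beyond the scatter) from compound 3 to compound 4; the limit leaves it open whether they differ.

The compounds shown leave open what a longer chain such as butyl, or a chain ending in an amine or a carboxylic acid, would do at either place. They also leave open whether the same direction would hold on any further core.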